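Cytotoxicity After Swapping an Ester Side Chain for Prenyl

The source may report more compounds than this note shows. Statements on the series, on what has been measured and on what is new or still open speak of the compounds shown alone.

Compound 1 `CCC1(Cc2ccccc2)OS(=O)(=O)C=C1OCC(=O)OC` was tested in an ADME assay on HEL cells (Homo sapiens) for cytotoxicity, with a stated time of 3 days; on this read-out higher numbers stand for lower toxicity in this test and lower numbers for higher toxicity in this test. In this assay compound 1 gives > 200000 nM, which is a limit of the assay rather than a number. Compound 1 therefore sits at the limit of > 200000 nM in this assay, at which 1 of the 3 values shown sits. Compound 2 `CCCC1(Cc2ccccc2)OS(=O)(=O)C=C1OCc1ccccc1` gives 200000 nM in this assay, and compound 3 `CCC1(CC)OS(=O)(=O)C=C1OCc1ccccc1` gives 200000 nM in this assay, so all three compounds sit at the high end of what this test reports.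

Compound 4 `CCC1(Cc2ccccc2)OS(=O)(=O)C=C1OCC=C(C)C` has not yet been measured in this assay. It differs from compound 1 by 2-methylprop-1-en-1-yl in place of methoxycarbonyl on a saturated chain carbon bound to an oxygen on an unsaturated carbon. For the measured compounds named here, no step between measured compounds is available, so the expectation rests on the values shown. Compound 4 is expected to show a step of a number no higher from compound 1 to compound 4 (the limit leaves the size open), that is, none beyond the scatter. Compound 4 is estimated to give 200000 nM, within a range from 80000 nM to 400000 nM, in this assay.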

Compound 4, half-maximal cytotoxic concentration: 112000 nM
Beside the measured number, compound 4's estimate is 1.8-fold (0.25 log units) above it; the measured number falls inside the stated range.
By their numbers in this assay, from the lowest: compounds 4, 2 and 3 (each within the scatter of the next).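

In this assay, 2-methylprop-1-en-1-yl in place of methoxycarbonyl gives an at least 1.7-fold lower number from compound 1 to compound 4 (0.25 log units; that floor lies within the scatter). For the compounds shown here, this is the first readable change at this position, and it shows that an all-carbon group can stand there with a measured number rather than a limit. The value of compound 1 is a limit, and the true size of the step stays open because of it: the limit of > 200000 nM in this assay, at which 1 of the 4 values shown sits.

On these data alone, whether an amine or a carboxylic acid at this position would move the number beyond the scatter remains open. So does the effect of a longer chain there.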